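Notes on the glutarimide-bearing series: compound 1 to compound 3

The compounds below may be only part of what the source reports. "The series", "measured", "known", "first", "only" and "open" are said of these compounds alone.

Among the compounds with values here, compound 1 `CN(c1ccccc1)c1ccc2c(c1)C(=O)N(C1CCC(=O)NC1=O)C2=O` stands lowest of the two numbers so far: in an assay on FRT-Jurkat cells for inhibition of nuclear factor NF-kappa-B complex (Homo sapiens), read by flow cytometry, with a stated time of 24 h, tested at 10 uM (a lower number here means less inhibition, a higher number more inhibition at the concentration tested (going by the name of the read-out)), compound 1 gives -2%. Within the data shown here, compound 2 `CCCCCc1ccc(Nc2cccc3c2C(=O)N(C2CCC(=O)NC2=O)C3=O)cc1` gives 23% in this assay, a gap beyond the usual scatter; no single-change step between these two compounds is available. Compound 3 `CCc1ccc(Nc2ccc3c(c2)C(=O)N(C2CCC(=O)NC2=O)C3=O)cc1` is not yet measured. It differs from compound 1 by (4-ethylphenyl)amino in place of methyl(phenyl)amino on an aromatic carbon. Because compound 2 gives 23%, an upward step a number 17 percentage points higher from compound 1 to compound 3 (beyond the scatter) is expected, modest in size and resting on that one number only. Compound 3 is estimated at 15%, within -5% to 35%.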

Compound 3, a percentage reported as inhibition, at one concentration (the size of the read-out at that concentration, not a potency): 5%
For compound 3 the middle estimate is 10 percentage points above the measured one, within the range that was stated.
By their numbers in this assay, from the lowest: compounds 1 and 3 (each within the scatter of the next); then compound 2.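

The step in this assay reads a number 7 percentage points higher from compound 1 to compound 3 (within the scatter), so at this position the data do not separate (4-ethylphenyl)amino from methyl(phenyl)amino, although the entering group carries a hydrogen-bond donor that the leaving group lacks. No measurement at hand bears on the reason for this result.

Within the data shown here, no single-change step links compound 2 to compound 1 or compound 3, so its value cannot be assigned to any one structural difference. Also open, from the compounds shown here alone, is whether a carboxylic acid or a primary amine in place of the ethyl on compound 3 would separate from compound 1.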